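A Second 3-methylbut-2-en-1-yl Group on Compound 2

The source may report more compounds than this note shows. Statements on the series, on what has been measured and on what is new or still open speak of the compounds shown alone.

In a functional assay on HeLa cells (Homo sapiens) for cytotoxicity, read by XTT assay, with a stated time of 72 h (a lower number here means a stronger inhibitor, a higher number a weaker inhibitor), compound 2 `CC(=O)c1c(O)cc(O)c(CC=C(C)C)c1O` gives 30000 nM and so stands level, within the scatter, with compound 3 `CC(C)=CCC/C=C(\C)Cc1c(O)cc(O)c2c(=O)c(O)c(-c3ccc(O)cc3)oc12` at 30000 nM on the same scale. Compound 1 `CCCCCCCC/C=C\CCCCCCCCc1c(O)cc(O)c(C(C)=O)c1O` shows > 100000 nM as a limit of the assay and not a number. Compound 4 `CC(=O)c1c(O)c(CC=C(C)C)c(O)c(CC=C(C)C)c1O` carries 3-methylbut-2-en-1-yl in place of hydrogen on an aromatic carbon of compound 2 (3-methylbut-2-en-1-yl in place of hydrogen on an aromatic carbon), ortho to two hydroxy groups. Among the compounds with values here, no pair of measured compounds shows this change on its own, so only a modest gain in inhibition is expected in this assay and the estimate stays wide. The estimated step is a 2.5-fold lower number from compound 2 to compound 4 (0.40 log units; beyond the scatter) and points toward stronger inhibition. Compound 4 is expected at 12000 nM (estimated range 3500 nM to 40000 nM).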

Compound 4, half-maximal inhibitory concentration: > 100000 nM
Compound 4: no number, only a limit; the forecaster's own chance of this, stated with the estimate: 10%; middle value at least 8.3-fold (0.92 log units) away from the limit.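

In this assay, within the data shown here, placing a second 3-methylbut-2-en-1-yl group on this aromatic carbon, ortho to two hydroxy groups, gives an at least 3.3-fold higher number from compound 2 to compound 4 (0.52 log units; beyond the scatter), the first reading for this position, and it points toward weaker inhibition. For compound 4, the reading is a limit of the assay and not a number, so the true size of the step stays unknown: the limit of > 100000 nM in this assay, at which 2 of the 4 values shown sit.

The compounds shown leave open how a methyl group, an amine or a carboxylic acid on this same carbon would behave.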